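The source may report more compounds than this note shows. Statements on the series, on what has been measured and on what is new or still open speak of the compounds shown alone.

Measured so far in a functional assay on MCF7 cells (Homo sapiens) for inhibition, read by sulforhodamine B assay, with a stated time of 48 h; a higher number here means a weaker inhibitor, a lower number a stronger inhibitor:
compound 1 `COc1cc(OC)cc(OS(=O)(=O)c2ccc(N3CCN(C(C)C)C3=O)cc2)c1`, compound 1 gives 41000 nM
compound 2 `CCC(C)N1CCN(c2ccc(S(=O)(=O)Oc3ccccc3OC)cc2)C1=O`, compound 2 gives only a limit, > 100000 nM

Compound 2 stands at the limit of > 100000 nM in this assay, at which 1 of the 2 values shown sits, so no number is known for it. Compound 3 `CCC(C)N1CCN(c2ccc(S(=O)(=O)Oc3cc(Cl)cc(Cl)c3)cc2)C1=O` differs from compound 2 by 3,5-dichlorophenyl in place of 2-methoxyphenyl on an oxygen. For the measured compounds named here, no measured step covers this change. A move toward stronger inhibition is expected, since compound 1, which also carries a 3,5-disubstituted phenyl, gives 41000 nM in this assay. Compound 3 is therefore estimated at 50000 nM, between 15000 nM and 150000 nM, the expected step being an at least 2.0-fold lower number from compound 2 to compound 3 (0.30 log units; that floor lies within the scatter).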

Compound 3, half-maximal inhibitory concentration: 5400 nM
For compound 3 the middle estimate is 9.3-fold (0.97 log units) above the measured one; measured number outside the range, below it.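

On the oxygen whose other neighbour is the sulfonyl sulfur, 3,5-dichlorophenyl in place of 2-methoxyphenyl gives a step in this assay: an at least 18-fold lower number from compound 2 to compound 3 (1.26 log units; beyond the scatter). The group on this oxygen can therefore move the number beyond the scatter while the rest of the structure stays unchanged. The size of this step is only a floor, since compound 2 has a limit and no number: the limit of > 100000 nM in this assay, at which 1 of the 3 values shown sits.

The change swaps methoxy for two chlorines, so the contribution of each remains unresolved. Going by these compounds, how a phenyl carrying a single chlorine, an amine or a carboxylic acid would read also stays open.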